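The source may hold more compounds than are shown below. What is called first, only, known or untested is meant among the compounds shown, and "the series" means these compounds.

Of the compounds shown here, three have been tested so far. In a functional assay on A549 cells (Homo sapiens) for antiproliferative activity, read by MTT assay, with a stated time of 72 h (a lower number here means a stronger inhibitor, a higher number a weaker inhibitor), compound 1 `CCNC(=O)c1cc(Oc2ccc(NC(=O)c3nn(-c4ccccc4C)c(=O)cc3C)cc2)ccn1` gives 34800 nM, compound 2 `CNC(=O)c1cc(Oc2ccc(NC(=O)c3nn(-c4ccccc4Cl)c(=O)cc3C)cc2F)ccn1` gives 11800 nM, and compound 3 `CCCNC(=O)c1cc(Oc2ccc(NC(=O)c3nn(-c4ccc(Br)cc4F)c(=O)cc3C)cc2F)ccn1` gives 235000 nM. Compound 2 stands lowest of the three, and its gaps to both compound 1 and compound 3 lie beyond the scatter, so it is the most potent of this small set. Compound 4 `CNC(=O)c1cc(Oc2ccc(NC(=O)c3nn(-c4cccc(C(F)(F)F)c4)c(=O)cc3C)cc2F)ccn1` has not yet been measured. It differs from compound 2 by one change: 3-(trifluoromethyl)phenyl in place of 2-chlorophenyl on an aromatic nitrogen. Within the data shown here, no directly comparable pair among the measured compounds shows what such a change does, so the step is expected to be modest and somewhat toward weaker inhibition, namely a 1.7-fold higher number from compound 2 to compound 4 (0.23 log units; within the scatter). In this assay compound 4 is expected to give about 20000 nM, with a range of 5000 nM to 80000 nM.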

Compound 4, half-maximal inhibitory concentration: 10200 nM
Compound 4: the middle estimate sits 2.0-fold (0.29 log units) above what was measured, and the stated range covers the measured number.
By their numbers in this assay, from the lowest: compounds 4 and 2 (each within the scatter of the next); then compound 1; then compound 3.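

In this assay, among these compounds, the place on the aromatic nitrogen takes 3-(trifluoromethyl)phenyl in place of 2-chlorophenyl with a 1.2-fold lower number from compound 2 to compound 4 (0.06 log units; within the scatter) as the step, the first reading at this position. A group with more heavy atoms, carrying its substituent at a different ring position and with fluorine in place of chlorine, thus leaves the two numbers within the scatter of each other. No measurement here accounts for this. Still open, as far as these compounds go, is how an unsubstituted phenyl, or a phenyl bearing an amine or a carboxylic acid, would read at this nitrogen.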